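Taking the butyl group off compound 1

The compounds below may be only part of what the source reports. "The series", "measured", "known", "first", "only" and "open" are said of these compounds alone.

In a functional assay on HEL cells (Homo sapiens) (a higher number here means that more compound is tolerated, a lower number that less compound is tolerated), compound 1 (`CCCCc1cc2cn(COCCO)c(=O)nc2o1`) gives > 200000 nM as a limit, not a number. Compound 3 (`CCCCCCCCCc1cc2cn(COCCO)c(=O)nc2o1`) gives >= 100000 nM as a limit too. Compound 2 (`CCCCCCCCCCCc1cc2cn(COCCO)c(=O)nc2o1`) gives 132000 nM as a true number. Compound 4 (`O=c1nc2occc2cn1COCCO`) has not been measured, and it differs from compound 1 by hydrogen in place of butyl on an aromatic carbon in the core. The nearest evidence comes from lengthening the butyl chain, which gives an at least 1.5-fold lower number from compound 1 to compound 2 (0.18 log units; that floor lies within the scatter) and also a step that the two limits leave unreadable from compound 1 to compound 3 as the other step. Going by the values given here, no measured step removes the chain, so these steps only suggest that the chain matters little here. The expected change is a number no higher from compound 1 to compound 4 (the limit leaves the size open) and it should stay within the scatter. Compound 4 is estimated at 200000 nM in this assay, with 100000 nM to 400000 nM as the expected range.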

Compound 4, half-maximal cytotoxic concentration: > 200000 nM
Compound 4: no number, only a limit; the forecaster's own chance of this, stated with the estimate: 65%; the middle value lies on the limit itself.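

Going by these compounds alone, compound 1 and compound 4 are each reported only as a limit, so no step between them can be read: the limit of > 200000 nM in this assay, at which 2 of the 4 values shown sit.

The compounds shown leave open whether replacing butyl with hydrogen changes the half-maximal cytotoxic concentration at all.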